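Swapping the indole of compound 1 for a carbamoylphenyl

This account rests on a few compounds, and the source may have more. Where it says the series, first, only, none or still open, it means among the compounds named here.

Going by the values given here, compound 1 `FC(F)(F)Oc1ccc(Nc2cc(-c3cccc4[nH]ccc34)ncn2)cc1` gives 3790 nM in an ADME assay on BaF3 cells (Mus musculus) for cytotoxicity (on this read-out higher numbers stand for an effect only at larger amounts of compound and lower numbers for an effect already at smaller amounts), the lowest of the two numbers measured so far; compound 2 `Cc1ccc(NC(=O)c2cccc(C(F)(F)F)c2)cc1C(=O)c1cc2c(Nc3ccc(OC(F)(F)F)cc3)ncnc2s1` gives 8900 nM in this assay, a gap that lies beyond the scatter. Compound 3 `NC(=O)c1ccc(-c2cc(Nc3ccc(OC(F)(F)F)cc3)ncn2)cc1` carries 4-carbamoylphenyl in place of 1H-indol-4-yl on an aromatic carbon. Among the compounds with values here, no measured pair shows this change, so its size is unknown; a step of about the scatter is expected, if anything toward a higher number. Compound 3 is expected to give 5000 nM in this assay, between 2000 nM and 12000 nM, an expected step of a 1.3-fold higher number from compound 1 to compound 3 (0.12 log units; within the scatter).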

Compound 3, half-maximal effective concentration: > 10000 nM
Compound 3: a limit, no number; the forecaster's own chance of this, stated with the estimate: 10%; at least 2.0-fold (0.30 log units) between middle value and limit.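

On the aromatic carbon of the shared core, 4-carbamoylphenyl in place of 1H-indol-4-yl gives an at least 2.6-fold higher number from compound 1 to compound 3 (0.42 log units; beyond the scatter) in this assay, so a change at this position can move the read-out beyond the scatter. Compound 3 stands at a limit of the assay and not at a number, and the full size of the step cannot be read because the read-out ends there: the limit of > 10000 nM in this assay, at which 1 of the 3 values shown sits.

The compounds shown do not separate the carbamoyl group from the loss of the indole. Going by these compounds, whether a plain phenyl, or an amine or carboxylic acid in place of the carbamoyl, moves the number the same way remains open.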